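Adding a Methyl to the Weaker of Two Compounds

The source may hold more compounds than are shown below. What is called first, only, known or untested is meant among the compounds shown, and "the series" means these compounds.

In a functional assay on HeLa cells (Homo sapiens) for cytotoxicity, read by MTT assay, with a stated time of 48 h (a higher number here means a weaker inhibitor, a lower number a stronger inhibitor), compound 1 (`COc1ccc(/C=C/c2cc(OC)c(OC)c(OC)c2-c2ccccc2)cc1`) gives 26000 nM, and compound 2 (`COc1cc(/C=C/c2ccccc2)c(-c2ccccc2)c(OC)c1OC`) gives 89000 nM, the higher of the two numbers. Compound 3 (`COc1cc(/C=C/c2ccc(C)cc2)c(-c2ccccc2)c(OC)c1OC`) differs from compound 2 by one change: methyl in place of hydrogen on an aromatic carbon. Among the measured compounds shown here, the only measured step bearing on this is a 3.4-fold higher number from compound 1 to compound 2 (0.53 log units; beyond the scatter), where hydrogen replaces methoxy on an aromatic carbon. Methyl is not methoxy, so only a small move toward a lower number is expected in this assay, estimated as a 1.8-fold lower number from compound 2 to compound 3 (0.25 log units; within the scatter). Compound 3 is expected at 50000 nM, with a range of 22000 nM to 110000 nM.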

Compound 3, half-maximal inhibitory concentration: 45000 nM
For compound 3 the middle estimate is 1.1-fold (0.05 log units) above the measured one; the measured number falls inside the stated range.
By their numbers in this assay, from the lowest: compounds 1, 3 and 2 (each within the scatter of the next, the first and the last beyond it).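

In this assay, placing methyl on this aromatic carbon gives a 2.0-fold lower number from compound 2 to compound 3 (0.30 log units; within the scatter), so compound 3 cannot be told apart from the compound carrying hydrogen there. Setting methyl against methoxy at the same carbon gives a 1.7-fold higher number from compound 1 to compound 3 (0.24 log units; within the scatter), so compound 3 cannot be told apart from that compound either, although the hydrogen and methoxy compounds themselves can be separated. No measurement at hand explains these results.

On these data alone, it remains open whether an amine, a carboxylic acid or a longer chain such as butyl at this carbon would give a clearly separate number.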